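Notes on acyl groups at the ring nitrogen

The source may hold more compounds than are shown below. What is called first, only, known or untested is meant among the compounds shown, and "the series" means these compounds.

The three measured compounds share one core with an amide to a hydroxyphenyl group and differ only at the ring nitrogen: compound 1 `CC(=O)N1c2ccccc2CCC1C(=O)Nc1ccccc1O` carries an acetyl there, compound 2 `O=C(Nc1ccccc1O)C1CCc2ccccc2N1C(=O)c1ccccc1` a benzoyl, and compound 3 `O=C(Nc1ccccc1O)C1CCc2ccccc2N1` a hydrogen. In a functional assay on MDA-MB-231 cells (Homo sapiens) for cytotoxicity, read by sulforhodamine B assay, with a stated time of 72 h (on this read-out higher numbers stand for weaker inhibition of growth and lower numbers for stronger inhibition of growth), compound 1 gives 89600 nM, compound 2 gives 4210 nM and compound 3 gives 5260 nM. Compound 3 stands second highest of the three numbers; the step of a 1.2-fold higher number from compound 2 to compound 3 (0.10 log units; within the scatter) lies within the scatter, whereas the step of a 17-fold lower number from compound 1 to compound 3 (1.23 log units; beyond the scatter) is large, as is a 21-fold lower number from compound 1 to compound 2 (1.33 log units; beyond the scatter). Compound 4 `O=C(Nc1ccccc1O)C1CCc2ccccc2N1C(=O)c1cccc(Cl)c1` carries (3-chlorophenyl)carbonyl in place of hydrogen on a nitrogen on an aromatic ring in a ring. The step that bears on it most directly is a 1.2-fold higher number from compound 2 to compound 3 (0.10 log units; within the scatter), the mirror of placing an aryl carbonyl on this nitrogen, and it stayed within the scatter; the steps of a 21-fold lower number from compound 1 to compound 2 (1.33 log units; beyond the scatter) and a 17-fold lower number from compound 1 to compound 3 (1.23 log units; beyond the scatter) show only that acetyl gives the weakest number at this position. Nothing measured here speaks to the chlorine. The step expected for compound 4 in this assay is therefore a 1.2-fold lower number from compound 3 to compound 4 (0.07 log units; within the scatter), within the scatter and in no firm direction. Compound 4 is estimated at 4500 nM, with a range from 1500 nM to 13000 nM.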

Compound 4, concentration for 50% growth inhibition: 10600 nM
Compound 4: middle estimate off by 2.4-fold (0.37 log units), on the low side, and the stated range covers the measured number.
By their numbers in this assay, from the lowest: compounds 2, 3 and 4 (each within the scatter of the next, the first and the last beyond it); then compound 1.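

In this assay, going by these compounds alone, the chloro on the aromatic carbon of the benzoyl group is the first change made within the acyl group beyond swapping it whole, and a 2.5-fold higher number from compound 2 to compound 4 (0.40 log units; beyond the scatter) is modest but beyond the scatter, so substitution on this phenyl ring does register in the read-out, here towards weaker inhibition of growth. Against the free nitrogen, the (3-chlorophenyl)carbonyl group still stays within the scatter, with a 2.0-fold higher number from compound 3 to compound 4 (0.30 log units; within the scatter), while an 8.5-fold lower number from compound 1 to compound 4 (0.93 log units; beyond the scatter) shows that a second aryl carbonyl also stands apart from acetyl, so this separation does not rest on benzoyl alone. No measurement on hand explains the chloro step or the separation from acetyl.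

As far as these compounds go, whether a fluoro or a methoxy on the phenyl ring would shift the number as chloro does remains open. So does whether a cyclohexylcarbonyl or a longer chain such as butanoyl on the nitrogen would fall with acetyl or with the aryl carbonyls.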